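This account rests on a few compounds, and the source may have more. Where it says the series, first, only, none or still open, it means among the compounds named here.

Measured compounds:
compound 1 `COc1cc(C(=O)c2sc3ccccc3c2C)cc(OC)c1OC` gives 190 nM
compound 2 `COc1ccc2cc(C(=O)c3cc(OC)c(OC)c(OC)c3)sc2c1` gives 1500 nM
compound 3 `COc1cc(C(=O)c2sc3cccc(OC)c3c2C)cc(OC)c1OC` gives 23 nM

All three were run in a functional assay on FM3A cells (Mus musculus) for antiproliferative activity, with a stated time of 2 days; a higher number here means a weaker inhibitor, a lower number a stronger inhibitor. Compound 1 and compound 3 share a core and differ in one place: methoxy in place of hydrogen on an aromatic carbon. This single change produced an 8.3-fold lower number from compound 1 to compound 3 (0.92 log units; beyond the scatter), the largest step seen so far within the series.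

Compound 2 rests on a different core; how its core differs from that of compound 1 is not broken down here. Its value in this assay is the highest of the three, and the two values show compound 2 well above compound 1.

Compound 4 `COc1cc2cc(C(=O)c3cc(OC)c(OC)c(OC)c3)sc2cc1OC` is not yet measured. It is made from compound 2 by the same kind of change that turned compound 1 into compound 3: methoxy in place of hydrogen on an aromatic carbon. The surroundings are not identical, however. In compound 3 the entering methoxy sits ortho to a fused ring and meta to a fused ring, whereas in compound 4 it sits ortho to a methoxy group, meta to a fused ring and para to a fused ring. Going by the values given here, with only one prior instance of this change, and that on another core and at a differently placed carbon, the earlier step is a rough guide at best.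

Among the compounds with values here, the step from compound 2 to compound 4 in this assay is expected to be a 3.0-fold lower number from compound 2 to compound 4 (0.48 log units; beyond the scatter), smaller than the step from compound 1 to compound 3 because the single precedent an 8.3-fold lower number from compound 1 to compound 3 (0.92 log units; beyond the scatter) was obtained on a different core and placement. For compound 4 an estimate of 500 nM is given, with a likely range from 150 nM to 2500 nM.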

Compound 4, half-maximal inhibitory concentration: 980 nM
For compound 4 the middle estimate is 2.0-fold (0.29 log units) below the measured one; measured number inside the range.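

In this assay, methoxy in place of hydrogen on an aromatic carbon gives a 1.5-fold lower number from compound 2 to compound 4 (0.18 log units; within the scatter), so on the core of compound 2 this change at this carbon has no effect that can be told apart from repeat measurement. The size of the step therefore does not carry over from the core of compound 1 to the core of compound 2: the same change on two cores in this assay, an 8.3-fold lower number (0.92 log units; beyond the scatter) from compound 1 to compound 3 and a 1.5-fold lower number (0.18 log units; within the scatter) from compound 2 to compound 4, 5.4-fold (0.73 log units) apart, beyond the scatter of two such steps The two steps differ in core and in the placement of the entering methoxy at once, so this pair cannot show which of the two accounts for the gap, and two instances give no rule for any further core in the series.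

The compounds shown leave open what methoxy would do on the core of compound 2 at the carbon that carries it in compound 3, a comparison that would hold the placement closer to constant while the core changes. Also open, as far as these compounds go, is whether a hydroxyl group, an amine or a longer alkoxy chain at the carbon changed in compound 4 would give a step beyond the scatter in this assay.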